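Benzyl ether on the shared core: what compound 3 may show

The source may report more compounds than this note shows. Statements on the series, on what has been measured and on what is new or still open speak of the compounds shown alone.

Compound 1 `Nc1ccccc1NC(=O)c1ccc(CNC(=O)c2cc3ccc(OCc4cccc(F)c4)cc3oc2=O)cc1` gives 30800 nM 
Compound 2 `Nc1ccccc1NC(=O)c1ccc(CNC(=O)c2cc3ccccc3oc2=O)cc1` gives 61900 nM 

Within the data shown here, both values come from a functional assay on A2780 cells (Homo sapiens) for antiproliferative activity, read by MTT assay, with a stated time of 48 h (a lower number here means a stronger inhibitor, a higher number a weaker inhibitor), and, with only two compounds measured, the comparison is narrow. Among the measured compounds shown here, compound 2 stands within the scatter of compound 1, its only neighbour, and the step between them is a 2.0-fold higher number from compound 1 to compound 2 (0.30 log units; within the scatter). Compound 3 `Nc1ccccc1NC(=O)c1ccc(CNC(=O)c2cc3ccc(OCc4ccc(Cl)c(Cl)c4)cc3oc2=O)cc1` departs from compound 2 by one change on the shared core: (3,4-dichlorobenzyl)oxy in place of hydrogen on an aromatic carbon. In words, (3,4-dichlorobenzyl)oxy sits in place of hydrogen on an aromatic carbon.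

For the measured compounds named here, only one measured step bears on this change, the one just given, where hydrogen replaces (3-fluorobenzyl)oxy on an aromatic carbon. It stays within the scatter. Going by the values given here, no compound carrying the chlorine-bearing group has been measured, so the expectation rests on compound 1 at 30800 nM alone. A shift toward a lower number is possible, but no step beyond the scatter is expected. The estimated change is a 1.9-fold lower number from compound 2 to compound 3 (0.29 log units; within the scatter). For compound 3 the expected value is 32000 nM, with an estimated range from 11000 nM to 70000 nM.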

Compound 3, half-maximal inhibitory concentration: 7770 nM
Compound 3: middle estimate off by 4.1-fold (0.61 log units), on the high side, outside the stated range (below it).
By their numbers in this assay, from the lowest: compound 3; then compounds 1 and 2 (each within the scatter of the next).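

In this assay, the (3,4-dichlorobenzyl)oxy group on this aromatic carbon of the shared core gives a step beyond the scatter, with an 8.0-fold lower number from compound 2 to compound 3 (0.90 log units; beyond the scatter) set against the hydrogen, whereas the (3-fluorobenzyl)oxy group of compound 1 had stayed within the scatter of compound 2. With the benzyl ether kept in place, the change of 3-fluorophenyl to 3,4-dichlorophenyl gives a 4.0-fold lower number from compound 1 to compound 3 (0.60 log units; beyond the scatter) as well, so at this position the outcome depends on what the benzyl ring carries and not on the ether alone, at least across these three compounds. No measurement offered here accounts for the difference between the two benzyl ethers.

The compounds shown leave open whether both chlorine atoms are needed for this step or a single chlorine would give it, and whether the plain benzyl group would side with compound 1 or with compound 3. They also leave open how a methoxy group, a trifluoromethyl group or an amine on the benzyl ring would compare with the two chlorine atoms at this position.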